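Moving the aminomethyl onto a cyclohexene ring

This account rests on a few compounds, and the source may have more. Where it says the series, first, only, none or still open, it means among the compounds named here.

Compound 2 `NC[C@H]1CC[C@H](CN(C[C@H]2Cc3ccccc3CN2)[C@H]2CCCc3cccnc32)CC1` is the weaker-looking of the two measured compounds, although its distance from compound 1 is small: in a functional assay on CCRF-CEM cells for antagonist activity at C-X-C chemokine receptor type 4 (Homo sapiens), read by calcium flux, with stated times of 25 min and 90 s (a higher number here means a weaker inhibitor, a lower number a stronger inhibitor), compound 2 gives 340 nM, while compound 1 `N[C@H]1CC[C@H](CN(C[C@H]2Cc3ccccc3CN2)[C@H]2CCCc3cccnc32)CC1` gives 280 nM, and the step of a 1.2-fold higher number from compound 1 to compound 2 (0.08 log units; within the scatter) stays within the scatter. Compound 3 `NCC1=C(CN(C[C@H]2Cc3ccccc3CN2)[C@H]2CCCc3cccnc32)CCCC1` has not been measured. It differs from compound 2 by 2-(aminomethyl)cyclohex-1-en-1-yl in place of 4-(aminomethyl)cyclohexyl on a saturated chain carbon bound to an amine nitrogen, so the ring loses its two defined stereocentres, gains a double bond, and the aminomethyl moves from the far side of the ring to the carbon next to the point of attachment. For the measured compounds named here, no measured step covers such a change; the only measured step, from compound 1 to compound 2, concerns the length of the amine arm and was flat. Going by the values given here, the new placement of the amine therefore has no precedent here, and the estimate for compound 3 is a modest loss, a 2.1-fold higher number from compound 2 to compound 3 (0.31 log units; beyond the scatter), with wide uncertainty. Compound 3 is expected to give about 700 nM in this assay, most likely between 150 nM and 3000 nM.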

Compound 3, half-maximal inhibitory concentration: 230 nM
For compound 3 the middle estimate is 3.0-fold (0.48 log units) above the measured one; low and high end bracket the measured number.
By their numbers in this assay, from the lowest: compounds 3, 1 and 2 (each within the scatter of the next).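

In this assay, putting 2-(aminomethyl)cyclohex-1-en-1-yl in place of 4-(aminomethyl)cyclohexyl gives a 1.5-fold lower number from compound 2 to compound 3 (0.17 log units; within the scatter), and putting the same group in place of 4-aminocyclohexyl gives a 1.2-fold lower number from compound 1 to compound 3 (0.09 log units; within the scatter). Until now only the length of the amine arm had varied, whereas these steps show that, on a saturated chain carbon bound to an amine nitrogen, a much larger change in the ring leaves the number within the scatter: the defined stereocentres are gone, a double bond has entered and the aminomethyl sits at a different ring position. No evidence is available on why the three compounds read alike.

The double bond and the moved aminomethyl arrive together in compound 3, and the compounds shown do not separate them, which a saturated 2-(aminomethyl)cyclohexyl group would do. As far as these compounds go, all three compounds also carry a primary amine on the ring, so it remains open whether the amine matters at all here, a question that a plain cyclohexyl or a hydroxymethyl in place of the aminomethyl would address.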